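A few compounds are considered here, and "the series" means these few. Any claim that something is new, unique, unknown or untested is made for them only; others in the source may bear on it.

In a functional assay on HepG2 cells (Homo sapiens) for inhibition, with a stated time of 72 h (a higher number here means a weaker inhibitor, a lower number a stronger inhibitor), compound 1 `COc1ccc(NC(=O)Nc2nc(Sc3c[nH]c4ccccc34)cc(N3CCCCC3)n2)cc1` gives 17100 nM and compound 3 `O=C(Nc1ccc(Cl)cc1)Nc1nc(Sc2c[nH]c3ccccc23)cc(N2CCCCC2)n1` gives 14800 nM, with a 1.2-fold lower number from compound 1 to compound 3 (0.06 log units; within the scatter) leaving the two level. Compound 2 `Cc1ccc(C)c(NC(=O)Nc2nc(Sc3c[nH]c4ccccc34)cc(N3CCCCC3)n2)c1` gives 6440 nM. Compound 1 therefore stands at the weaker end of the three, alongside compound 3, with a 2.7-fold lower number from compound 1 to compound 2 (0.42 log units; beyond the scatter) and a 2.3-fold higher number from compound 2 to compound 3 (0.36 log units; beyond the scatter). Compound 4 `COc1ccc(NC(=O)Nc2nc(Sc3c[nH]c4ccccc34)cc(N3CCCC3)n2)cc1` carries this change: pyrrolidin-1-yl in place of piperidin-1-yl on an aromatic carbon. All three measured steps alter the substituted phenyl on the amide-type nitrogen, and none touches the piperidin-1-yl group. Going by the values given here, they therefore show only that steps so far are modest, and no step beyond the scatter is expected in this assay. Compound 4 is estimated at 15000 nM, with an expected range of 6000 nM to 35000 nM. The expected step is a 1.1-fold lower number from compound 1 to compound 4 (0.06 log units; within the scatter).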

Compound 4, half-maximal inhibitory concentration: 20300 nM
Estimate against measurement, compound 4: 1.4-fold (0.13 log units) below, within the range that was stated.
By their numbers in this assay, from the lowest: compound 2; then compounds 3, 1 and 4 (each within the scatter of the next).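

In this assay, going by these compounds alone, the first change at this position, pyrrolidin-1-yl in place of piperidin-1-yl, gives a 1.2-fold higher number from compound 1 to compound 4 (0.07 log units; within the scatter) and leaves the two compounds level. With the 4-methoxyphenyl group on the amide-type nitrogen, the five-membered and six-membered non-aromatic rings therefore cannot be told apart at this position. No available evidence bears on this result.

As far as these compounds go, whether the two rings also stay level alongside the 2,5-dimethylphenyl group of compound 2 remains open. Also open, from the compounds shown here alone, is what a morpholin-4-yl ring or an open-chain diethylamino group would give at this position.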